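The source may hold more compounds than are shown below. What is called first, only, known or untested is meant among the compounds shown, and "the series" means these compounds.

Measured so far in a physicochemical assay for solubility, measured as thermodynamic solubility, with a stated time of 24 h, at pH 6.8; a lower number here means a less soluble compound, a higher number a more soluble compound:

Compound 1, `CC1CCC(NC(=O)c2cc3c(Cl)cc(Cl)cc3[nH]2)CC1`, gives only a limit of the assay, < 4000 nM.
Compound 2, `CC1CCC(NC(=O)c2cc3c(F)cc(F)cc3[nH]2)CC1`, gives only a limit of the assay, < 4000 nM.
Compound 3, `CC1(C)CCC(NC(=O)c2cc3c(Cl)cc(Cl)cc3[nH]2)CC1`, gives only a limit of the assay, < 4000 nM.

Notes. Within the data shown here, every value so far sits at the limit of < 4000 nM in this assay, at which 3 of the 3 values shown sit, so no number in this assay has yet been read for this series. The cores of compound 1 and compound 2 differ, but that difference is not broken down here. Compound 1 and compound 3 share a core and differ by methyl in place of hydrogen on a saturated ring carbon; the step that the two limits leave unreadable from compound 1 to compound 3 cannot be sized, as both ends are limits.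

Compound 4, `CC1(C)CCC(NC(=O)c2cc3c(F)cc(F)cc3[nH]2)CC1`, is still to be measured in this assay. Against compound 2 it carries methyl in place of hydrogen on a saturated ring carbon, which is the same change as that from compound 1 to compound 3, made on the same place of the saturated ring.

Among the measured compounds shown here, the step from compound 2 to compound 4 in this assay is estimated at a step that the limit leaves unreadable from compound 2 to compound 4, a working assumption of no readable movement, because the limit of < 4000 nM in this assay, at which 3 of the 3 values shown sit, leaves the one measured instance of this change without a size. For compound 4 in this assay the expected value is 1500 nM, with a range from 200 nM to 4500 nM, and most likely a fourth limit rather than a number.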

Compound 4, solubility: < 4000 nM
Compound 4 was reported as a limit; the forecaster's own chance of this, stated with the estimate: 85%; the middle value is on the limit's open side.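

No new step can be read between compound 2 and compound 4 in this assay, because neither gives a number and both rest on the same limit: the limit of < 4000 nM in this assay, at which 4 of the 4 values shown sit.

The compounds shown leave open what number any of them would give in this assay, and whether methyl in place of hydrogen on a saturated ring carbon moves the read-out at all.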